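This account rests on a few compounds, and the source may have more. Where it says the series, first, only, none or still open, it means among the compounds named here.

Measured so far in a functional assay on KB cells (Homo sapiens) for antiproliferative activity, read by sulforhodamine B assay, with a stated time of 3 days; a higher number here means a weaker inhibitor of growth, a lower number a stronger inhibitor of growth:
- compound 1 `O=C(Nc1ccccn1)c1cccc(Nc2ncc(F)c(Nc3ccc(F)cc3)n2)c1`: 20000 nM
- compound 2 `COc1ccc(NC(=O)c2cccc(Nc3ncc(F)c(Nc4ccc(F)cc4)n3)c2)cc1`: a limit of the assay, > 10000 nM

Going by the values given here, compound 1 carries the only number in this assay; the one other value shown is a limit, not a number. The step from compound 1 to compound 2, a step that the limit leaves unreadable from compound 1 to compound 2, cannot be read for size, since the value of compound 2 sits at the limit of > 10000 nM in this assay, at which 1 of the 2 values shown sits.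

Compound 3 `O=C(Nc1cccc(Nc2ncc(F)c(Nc3ccc(F)cc3)n2)c1)c1cnccn1` is the next candidate. It differs from compound 1 as ((pyrazin-2-yl)carbonyl)amino in place of (pyridin-2-yl)carbamoyl on an aromatic carbon. Among the compounds with values here, the only measured step that changes the same part of the molecule is the one from compound 1 to compound 2, and that one is unreadable, so no step of known size bears on the present change. With compound 1 itself already weak in this assay, compound 3 is expected to remain in the weak range, with a step from compound 1 of a 1.3-fold lower number from compound 1 to compound 3 (0.12 log units; within the scatter), not clearly beyond the scatter in either direction. Compound 3 is estimated at 15000 nM, with a range from 3000 nM to 60000 nM, and a real chance that this assay returns only a limit for it.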

Compound 3, concentration for 50% growth inhibition: 23600 nM
Compound 3: middle estimate off by 1.6-fold (0.20 log units), on the low side; measured number inside the range.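

In this assay, going by these compounds alone, ((pyrazin-2-yl)carbonyl)amino in place of (pyridin-2-yl)carbamoyl on an aromatic carbon, meta to a large group, gives a 1.2-fold higher number from compound 1 to compound 3 (0.07 log units; within the scatter), the first step at this position that can be read for size. The entering group carries one six-membered aromatic ring with 2 hetero atoms where the leaving group carries one with 1 hetero atom, and it has one more hydrogen-bond acceptor, yet this exchange does not separate compound 1 from compound 3 in this assay. The steps that involve compound 2 cannot be read, because the value of compound 2 is a limit: the limit of > 10000 nM in this assay, at which 1 of the 3 values shown sits.

Going by these compounds, the exchange alters the amide linkage and the ring together, so their separate contributions stay open; ((pyridin-2-yl)carbonyl)amino at the same place would divide the two. Also open, on these data alone, is whether any group at this position moves the series out of the weak range, for instance a carboxylic acid or a morpholine on the amide in place of the aromatic ring.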